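From methoxy to ethoxy in a chemokine receptor antagonist series

The compounds below may be only part of what the source reports. "The series", "measured", "known", "first", "only" and "open" are said of these compounds alone.

Measured in a functional assay on CHO-K1 cells for antagonist activity at C-X-C chemokine receptor type 3 (Homo sapiens), read by FLIPR, with a stated time of 10 min; a lower number here means a stronger inhibitor, a higher number a weaker inhibitor:
Compound 1 `Cc1nc(C)n(CC(=O)N2CCN(c3sc(C(F)(F)F)nc3-c3cnc(C(C)(C)C)nc3)C[C@H]2C)n1`: 8.7 nM
Compound 2 `COc1ccc(-c2nc(C(F)(F)F)sc2N2CCN(C(=O)Cn3nc(C)nc3C)[C@H](C)C2)cn1`: 18 nM

For the measured compounds named here, compound 2 holds the higher of the two numbers; the only measured step, a 2.1-fold higher number from compound 1 to compound 2 (0.32 log units; beyond the scatter), comes from swapping the aryl group itself. Compound 3 `CCOc1ccc(-c2nc(C(F)(F)F)sc2N2CCN(C(=O)Cn3nc(C)nc3C)[C@H](C)C2)cn1` differs from compound 2 by methyl in place of hydrogen on a saturated chain carbon bound to an oxygen on an aromatic ring. Going by the values given here, no measured step touches this chain, so nothing recorded bears directly on it; the one known step concerns a different part of the molecule. A small alkyl extension of this kind is expected to leave the number unchanged within scatter, so the expected step is no change at the digits printed from compound 2 to compound 3 (within the scatter). Compound 3 is estimated at 18 nM, within 7 nM to 45 nM.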

Compound 3, half-maximal inhibitory concentration: 8.8 nM
Estimate against measurement, compound 3: 2.0-fold (0.31 log units) above; measured number inside the range.
By their numbers in this assay, from the lowest: compounds 1 and 3 (each within the scatter of the next); then compound 2.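

In this assay, adding a single methyl to turn 6-methoxypyridin-3-yl into 6-ethoxypyridin-3-yl gives a 2.0-fold lower number from compound 2 to compound 3 (0.31 log units; beyond the scatter), so this chain carbon bound to the oxygen responds to one extra carbon. The 6-ethoxypyridin-3-yl group also matches the 2-(tert-butyl)pyrimidin-5-yl group, with a 1.0-fold higher number from compound 1 to compound 3 (0.00 log units; within the scatter), which closes the earlier gap between these two aryl groups. No supporting data explain this step. Still open, going by these compounds, is whether a longer chain, such as propoxy, would continue the trend, or whether a cyclopropylmethoxy group or an amine at this position would hold the number.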